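The source may hold more compounds than are shown below. What is called first, only, known or untested is meant among the compounds shown, and "the series" means these compounds.

Of the compounds shown here, two built on a shared core have been tested in a functional assay on RAW264.7 cells (Mus musculus) for cytotoxicity, read by MTT assay, with a stated time of 48 h, tested at 50 uM; a higher number here means a stronger effect of the compound at the concentration tested, a lower number a weaker effect. Compound 1 `CS(=O)(=O)c1ccc(Cc2nnc3n2N=C(c2cc(Cl)sc2S(N)(=O)=O)CS3)cc1` gives 27.5% there. Compound 2 `CS(=O)(=O)c1ccc(Cc2nnc3n2N=C(c2cc(Cl)sc2Cl)CS3)cc1` gives 25.5%. Among the measured compounds shown here, the only change between them is a chloro in place of a sulfamoyl on an aromatic carbon, and the step of a number 2 percentage points lower from compound 1 to compound 2 (within the scatter) shows that this swap left the read-out essentially unchanged. Compound 2 thus stands together with compound 1, the two numbers lying within the usual scatter of each other.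

Compound 3 `Cc1ccc(C2=Nn3c(Cc4ccc(S(C)(=O)=O)cc4)nnc3SC2)cc1` differs from compound 2 in one place: 4-methylphenyl in place of 2,5-dichlorothiophen-3-yl on a carbon with a double bond to nitrogen. This is a different kind of change from the one measured so far, which exchanged a single substituent rather than a whole ring. For the measured compounds named here, no measured step bears directly on it; the one step available, a number 2 percentage points lower from compound 1 to compound 2 (within the scatter), was within the scatter. With so little to go on, the cautious expectation is that compound 3 stays near compound 2 in this assay, with no step beyond the scatter, although the untested nature of the change calls for a wide range. The expected step is a number 1.5 percentage points lower from compound 2 to compound 3 (within the scatter). For compound 3 the estimate is 24%, with a range from 8% to 42%.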

Compound 3, a percentage reported as activity, at one concentration (the size of the read-out at that concentration, not a potency): 37.9%
Estimate against measurement, compound 3: 13.9 percentage points below, and the stated range covers the measured number.
By their numbers in this assay, from the lowest: compounds 2 and 1 (each within the scatter of the next); then compound 3.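

Exchanging the whole ring on the carbon with a double bond to nitrogen moves the read-out in this assay in a way the sulfamoyl-to-chloro swap on that ring did not: 4-methylphenyl in place of 2,5-dichlorothiophen-3-yl gives a number 12.4 percentage points higher from compound 2 to compound 3 (beyond the scatter), and 4-methylphenyl in place of 5-chloro-2-sulfamoylthiophen-3-yl gives a number 10.4 percentage points higher from compound 1 to compound 3 (beyond the scatter). So at this position, the identity of the ring counts for more than the chloro or sulfamoyl group it carries, and both thiophene-bearing compounds sit apart from the carbon-only ring of compound 3, though each step is modest and comes from a single test concentration. Nothing at hand explains why the read-out rises with this change.

Going by these compounds, whether the rise belongs to the six-membered carbon ring itself or to its methyl stays open, and a plain phenyl, a 4-chlorophenyl or a phenyl carrying a carboxylic acid would separate the two. On these data alone, all three compounds also keep the rest of the core unchanged, so it is unknown whether the step would hold with an amine or a longer chain in place of the methylsulfonyl group.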